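A few compounds are considered here, and "the series" means these few. Any claim that something is new, unique, unknown or untested is made for them only; others in the source may bear on it.

Measured compounds:
Compound 1 `COc1cc2c(Oc3ccc(NC(=O)c4cn(-c5ccccc5)nn4)cc3F)ccnc2cc1OCCCN1CCC(C)CC1` — in a functional assay on NCI-H460 cells (Homo sapiens) for cytotoxicity, read by MTT assay, with a stated time of 72 h (on this read-out higher numbers stand for weaker inhibition and lower numbers for stronger inhibition), compound 1 gives 210 nM.
Compound 2 `COc1cc2c(Oc3ccc(NC(=O)c4cn(-c5c(C)cccc5C)nn4)cc3F)ccnc2cc1OCCCN1CCC(C)CC1` — in this assay compound 2 gives 2360 nM.
Compound 3 `COc1cc2c(Oc3ccc(NC(=O)c4cn(-c5ccc(F)c(F)c5)nn4)cc3F)ccnc2cc1OCCCN1CCC(C)CC1` — in this assay compound 3 gives 260 nM.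

Compound 3 holds the second highest of the three numbers. Its nearest neighbour is compound 1, with a 1.2-fold higher number from compound 1 to compound 3 (0.09 log units; within the scatter), a difference within the scatter, so no order can be read between these two. The furthest is compound 2, with a 9.1-fold lower number from compound 2 to compound 3 (0.96 log units; beyond the scatter); the remaining measured step, an 11-fold higher number from compound 1 to compound 2 (1.05 log units; beyond the scatter), is the counterpart on the same aryl group.

Compound 4 `COc1cc2c(Oc3ccc(NC(=O)c4cn(-c5ccc(F)c(F)c5)nn4)cc3F)ccnc2cc1OCCCN1CCN(C)CC1` differs from compound 3 by 4-methylpiperazin-1-yl in place of 4-methylpiperidin-1-yl on a saturated chain carbon, three bonds along the chain from an oxygen on an aromatic ring. None of the three measured steps touches this part of the molecule: each of them exchanges the aryl group on an aromatic nitrogen and leaves the saturated chain and its terminal ring unchanged. There is thus no measured evidence for how this exchange acts in this assay. The expected step from compound 3 to compound 4 is accordingly none beyond the scatter, no change at the digits printed from compound 3 to compound 4 (within the scatter). Compound 4 is therefore estimated at 260 nM, with a range from 90 nM to 750 nM, and the width of that range reflects the absence of any step that bears on the change.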

Compound 4, half-maximal inhibitory concentration: 250 nM
Compound 4: middle estimate off by 1.0-fold (0.02 log units), on the high side; the range from low to high includes it.
By their numbers in this assay, from the lowest: compounds 1, 4 and 3 (each within the scatter of the next); then compound 2.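

Of the steps shown, this is the only one that touches the saturated chain and its terminal ring rather than the aryl group on an aromatic nitrogen, and in this assay it gives a 1.0-fold lower number from compound 3 to compound 4 (0.02 log units; within the scatter), so no order can be read between the two terminal rings. With 3,4-difluorophenyl on the aromatic nitrogen, the second ring nitrogen of 4-methylpiperazin-1-yl thus leaves the read-out within the scatter, whereas the exchange on the aryl group gave an 11-fold higher number from compound 1 to compound 2 (1.05 log units; beyond the scatter), which lies beyond it. Nothing shown here bears on why the two terminal rings give numbers within the scatter of each other.

From the compounds shown here alone, it remains open whether the same exchange would also stay within the scatter with the phenyl group of compound 1 or the 2,6-dimethylphenyl group of compound 2, since this step stands on 3,4-difluorophenyl alone. Also open, going by these compounds, is how this assay would respond to a morpholine or a dimethylamino group at the end of the chain, or to a chain shorter or longer than the propyl chain of compound 3 and compound 4.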